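The source may report more compounds than this note shows. Statements on the series, on what has been measured and on what is new or still open speak of the compounds shown alone.

Series notes, sulfonamide set. The parent of the set is compound 1 `O=C(c1ccccc1)c1cccc(NS(=O)(=O)c2ccc(Cl)cc2Cl)c1`. In an assay on CHO cells for binding affinity to integrin alpha-1 (Homo sapiens), read by WST assay, with a stated time of 2 h (a lower number here means that less compound is needed, a higher number that more compound is needed for the effect), compound 1 gives 17000 nM. For the measured compounds named here, this is the only number available in the set so far: compound 2 `CN(c1cccc(C(=O)c2ccccc2)c1)S(=O)(=O)c1ccc(Cl)cc1Cl`, which carries a methyl on the sulfonamide nitrogen, is reported in this assay as "not active" (no number reported) and without a single number, so no step between measured compounds can be drawn from it, and compound 1 stands alone as the single numbered point.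

The next compound to be measured is compound 3 `O=C(c1ccccc1)c1cccc(NS(=O)(=O)c2ccc(Br)cc2)c1`. It differs from compound 1 as follows: 4-bromophenyl in place of 2,4-dichlorophenyl on a sulfonyl sulfur. Going by the values given here, no measured pair in the set shows what such a change does, so the expectation must rest on compound 1 alone. The working expectation is that the step from compound 1 to compound 3 is small, a 1.5-fold higher number from compound 1 to compound 3 (0.17 log units; within the scatter), leaning if anything toward a slightly weaker value, but not beyond the usual scatter with any confidence. On that basis compound 3 is estimated at 25000 nM in this assay, with a range from 8000 nM to 80000 nM, and a real chance that only a limit is reported.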

Compound 3, half-maximal effective concentration: 16000 nM
Compound 3: middle estimate off by 1.6-fold (0.19 log units), on the high side; measured number inside the range.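

In this assay, for the compounds shown here, the first readable step in the set is a 1.1-fold lower number from compound 1 to compound 3 (0.03 log units; within the scatter), obtained with 4-bromophenyl in place of 2,4-dichlorophenyl on a sulfonyl sulfur. The position therefore accepts this exchange without a readable change in the number, and the two groups cannot be told apart in this assay; this is a statement about one pair only, and it does not extend to other groups at this place. No supporting data bear on why the two compounds read alike.

The compounds shown leave open whether any group on the sulfonyl sulfur moves the number beyond the scatter, for example an unsubstituted phenyl, a carboxylic acid on the aromatic ring, an amine or a longer alkyl chain in place of the aryl group. Compound 2 has no numerical value, so the step to it cannot be read, and the methyl on the sulfonamide nitrogen remains unquantified, as does any change made elsewhere on the shared core.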